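This account rests on a few compounds, and the source may have more. Where it says the series, first, only, none or still open, it means among the compounds named here.

Measured compounds:
Compound 1, `C#CCCCn1c(Cc2cc(OC)c(OC)c(OC)c2)nc2c(N)ncnc21`, gives 24000 nM in a functional assay on MCF7 cells (Homo sapiens) for antiproliferative activity; a higher number here means a weaker inhibitor, a lower number a stronger inhibitor.
Compound 2, `CCCn1c(Cc2cc(OC)c(OC)c(OC)c2)nc2c(N)ncnc21`, gives 46800 nM in this assay.

Among the compounds with values here, compound 2 holds the highest of the two numbers in this assay, and its only neighbour is compound 1, reached by a 2.0-fold higher number from compound 1 to compound 2 (0.29 log units; within the scatter), so the two values cannot be told apart. Compound 3, `CCC(C)Cn1c(Cc2cc(OC)c(OC)c(OC)c2)nc2c(N)ncnc21`, has not yet been measured. It differs from compound 2 by ethyl in place of hydrogen on a saturated chain carbon bound to two saturated chain carbons. Within the data shown here, the only measured step that bears on this is the one from compound 1 to compound 2, which changes a group on the same saturated chain: a 2.0-fold higher number from compound 1 to compound 2 (0.29 log units; within the scatter), a step that stays within the scatter. That step alters the chain at a different carbon and exchanges a different group, so it is an imperfect guide, but it indicates that such chain changes on this core have produced no clear movement in this assay. Compound 3 is therefore expected to differ from compound 2 by a 1.3-fold lower number from compound 2 to compound 3 (0.13 log units; within the scatter), a step not beyond the scatter. Compound 3 is estimated at 35000 nM, with a range of 12000 nM to 100000 nM.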

Compound 3, half-maximal inhibitory concentration: 61700 nM
Compound 3: middle estimate off by 1.8-fold (0.25 log units), on the low side, within the range that was stated.
By their numbers in this assay, from the lowest: compounds 1, 2 and 3 (each within the scatter of the next, the first and the last beyond it).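

In this assay, ethyl in place of hydrogen on a saturated chain carbon bound to two saturated chain carbons, which turns the propyl chain of compound 2 into the 2-methylbutyl chain of compound 3, gives a 1.3-fold higher number from compound 2 to compound 3 (0.12 log units; within the scatter), so these two chains cannot be told apart here. Within the data shown here, compound 3 also provides the first step beyond the scatter in this small set: sec-butyl in place of but-3-yn-1-yl on a saturated chain carbon bound to an aromatic nitrogen gives a 2.6-fold higher number from compound 1 to compound 3 (0.41 log units; beyond the scatter), a modest separation, while compound 2 remains within the scatter of both compound 1 and compound 3. Nothing available offers an explanation for either step.

These compounds leave open whether the separation between compound 1 and compound 3 depends on the ethynyl end of the chain or on the ethyl branch, since the two chains differ in both features at once. They also leave open whether a chain ending in an amine or a carboxylic acid, or a longer chain, would move the number clearly away from those of the three compounds on this shared core.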